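The source may report more compounds than this note shows. Statements on the series, on what has been measured and on what is new or still open speak of the compounds shown alone.

Measured so far in an ADME assay on the whole organism for pharmacokinetics, with Homo sapiens as the target; a lower number here means that a smaller share of the oral dose reaches the circulation, a higher number that a larger share of the oral dose reaches the circulation:
Compound 1 `O=C(NS(=O)(=O)c1ccc2nc(-c3ccccc3)c(-c3ccccc3)nc2c1)c1ccccc1`: 100%
Compound 2 `O=S(=O)(Nc1ccc(O)cc1)c1ccc2nc(-c3ccccc3)c(-c3ccccc3)nc2c1`: 93.9%

Among the compounds with values here, compound 2 holds the lower of the two numbers in this assay; its only neighbour is compound 1, and the step of a number 6.1 percentage points lower from compound 1 to compound 2 (within the scatter) stays within the scatter, so the two compounds cannot be told apart on this read-out.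

Compound 3 `Cc1ccnc(NS(=O)(=O)c2ccc3nc(-c4ccccc4)c(-c4ccccc4)nc3c2)c1` is compound 2 with 4-methylpyridin-2-yl in place of 4-hydroxyphenyl on a sulfonamide nitrogen. Within the data shown here, the sole step measured so far, a number 6.1 percentage points lower from compound 1 to compound 2 (within the scatter), touches the same sulfonamide nitrogen and did not move this assay beyond the scatter. On that basis a replacement at this position is expected to leave the read-out essentially where it is, and the step of a number 3.9 percentage points lower from compound 2 to compound 3 (within the scatter) is therefore estimated to stay within the scatter. For compound 3 an oral bioavailability of 90% is expected, with a range from 70% to 100%; the lower end allows for the fact that compound 2 already sits slightly under compound 1.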

Compound 3, oral bioavailability: 100%
Beside the measured number, compound 3's estimate is 10 percentage points below it; the range from low to high includes it.
By their numbers in this assay, from the lowest: compounds 2, 1 and 3 (each within the scatter of the next).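

With the step of a number 6.1 percentage points higher from compound 2 to compound 3 (within the scatter) and the step of no change at the digits printed from compound 1 to compound 3 (within the scatter), this assay now covers three different groups on the sulfonamide nitrogen, and none can be told apart from another on this read-out. The position therefore also accepts 4-methylpyridin-2-yl, a six-membered aromatic ring with a hetero atom and no hydrogen-bond donor, so neither the hydroxyl of 4-hydroxyphenyl nor the carbonyl of benzoyl is required to stay within the scatter in this set of compounds. No supporting data bear on why the read-out stays level across these groups.

Open, from the compounds shown here alone, is whether the same holds for a quite different group on this nitrogen, such as a carboxylic acid, an amine or a longer alkyl chain. The compounds shown also leave open how this assay responds to any change on the shared core.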